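The compounds below may be only part of what the source reports. "The series", "measured", "known", "first", "only" and "open" are said of these compounds alone.

Compound 1, `CC(C#Cc1cccc(C(=O)NCCC(c2ccccc2)c2ccc(OC(F)(F)F)cc2)c1)N(O)C(N)=O`: 110 nM
Compound 2, `CC(C#Cc1cccc(C(=O)NCCC(c2ccccc2)c2ccc(C(F)(F)F)cc2)c1)N(O)C(N)=O`: 150 nM

Within the data shown here, in an assay for inhibition of Polyunsaturated fatty acid 5-lipoxygenase (Homo sapiens), read by HPLC, with stated times of 15 min and 10 min (on this read-out higher numbers stand for weaker inhibition and lower numbers for stronger inhibition), compound 2 gives 150 nM, the higher of the two numbers measured so far, and compound 1 gives 110 nM. The step of a 1.4-fold higher number from compound 1 to compound 2 (0.13 log units; within the scatter) lies within the scatter, so on this read-out the two compounds cannot be told apart. Compound 3, `CC(C#Cc1cccc(C(=O)NCCC(c2ccccc2)c2ccc(Cl)cc2)c1)N(O)C(N)=O`, keeps the shared core and changes one group only: chloro in place of trifluoromethyl on an aromatic carbon. Among the measured compounds shown here, the single measured step that bears on this change is a 1.4-fold higher number from compound 1 to compound 2 (0.13 log units; within the scatter), in which one small group was exchanged for another at the same place and the number hardly moved. That is a weak hint that this place tolerates an exchange of small groups without a large shift in the number. For the measured compounds named here, no measured pair shows a chloro group at this place, so the expectation rests on that one step alone. The step of a 1.2-fold lower number from compound 2 to compound 3 (0.06 log units; within the scatter) is therefore expected to stay within the scatter. The estimate for compound 3 is 130 nM, with a likely range from 60 nM to 300 nM.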

Compound 3, half-maximal inhibitory concentration: 120 nM
Compound 3: middle estimate off by 1.1-fold (0.03 log units), on the high side, within the range that was stated.
By their numbers in this assay, from the lowest: compounds 1, 3 and 2 (each within the scatter of the next).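

Replacing trifluoromethyl with chloro, which takes the group from four heavy atoms to one, gives a step in this assay that stays within the scatter (a 1.3-fold lower number from compound 2 to compound 3 (0.10 log units; within the scatter)), and replacing trifluoromethoxy with chloro does the same (a 1.1-fold higher number from compound 1 to compound 3 (0.04 log units; within the scatter)). The earlier pair compared only two fluorinated groups, whereas these steps add a group without fluorine and show that, among these three compounds, a single chlorine atom on this aromatic carbon, para to a large group, cannot be told apart from either fluorinated group on this read-out. No measurement is available to explain why these three groups give such closely matching numbers.

From the compounds shown here alone, all three compounds carry a halogen-containing group at this place, so it remains open whether the number would hold with a plain hydrogen, an amine, a carboxylic acid or a longer chain such as butyl. Going by these compounds, it also remains open whether chloro would behave in the same way on another carbon of this ring or on the unsubstituted phenyl ring of the shared core.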